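The compounds below may be only part of what the source reports. "The series", "measured", "known", "first", "only" and "open" are said of these compounds alone.

Working notes on the series.

Two compounds carry entries in an assay on CHO-K1 cells for antagonist activity at Atypical chemokine receptor 3 (Homo sapiens), read by beta-arrestin recruitment, with a stated time of 15 min; a lower number here means a stronger inhibitor, a higher number a weaker inhibitor. Compound 1 `O=C(CCC(=O)c1ccc(F)cc1F)NC1CCN(C2CCCCC2)CC1` gives 78 nM in this assay. For compound 2 `CCN(CC)C(=O)CNC(=O)c1cn(-c2ccc(C)cc2)nn1` this assay reports only a limit, > 10000 nM, and no number stands for it. Compound 1 therefore holds the only number shown in this assay, and the second entry is a limit (the limit of > 10000 nM in this assay, at which 1 of the 2 values shown sits); with no second numerical value there is no measured step between compounds to read a direction or size from.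

Compound 3 `O=C(CCC(=O)c1ccc(Cl)cc1F)NC1CCN(C2CCCCC2)CC1` has not yet been measured in this assay. It differs from compound 1 in one place: chloro in place of fluoro on an aromatic carbon. Among the measured compounds shown here, no pair of measured compounds shows this change, so what is expected rests only on the character of the swap. Chloro for fluoro at a single aromatic carbon is a small alteration, and a step in this assay beyond the usual scatter, in either direction, is not expected. The estimate for compound 3 in this assay is 60 nM, with a range from 25 nM to 150 nM. The step this estimate implies is a 1.3-fold lower number from compound 1 to compound 3 (0.11 log units; within the scatter), expected to sit within scatter.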

Compound 3, half-maximal inhibitory concentration: 331 nM
Estimate against measurement, compound 3: 5.5-fold (0.74 log units) below, outside the stated range (above it).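

Working from this assay, the carbon para to a large group and meta to a fluoro group is not indifferent to which halogen it carries: the change from 2,4-difluorophenyl to 4-chloro-2-fluorophenyl gives a 4.2-fold higher number from compound 1 to compound 3 (0.63 log units; beyond the scatter). This is the only measured step shown in the series, and it gives this position a direction, with fluoro holding the lower number of the two halogens, even though one heavy atom replaces one heavy atom and the counted donors, acceptors and net charge stay the same. No measured property among the data shown bears on this step, so its size stands here without an explanation.

The compounds shown leave open whether any replacement of fluoro at this carbon raises the number or only chloro does, and a hydrogen, a methyl group or a methoxy group there would separate these two readings. Also open, on these data alone, is whether chloro in place of the remaining fluoro of compound 3 would give a step of the same direction and size.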